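This account rests on a few compounds, and the source may have more. Where it says the series, first, only, none or still open, it means among the compounds named here.

Of the compounds shown here, three that share one core have been tested in a functional assay on HEK293 cells for agonist activity at Bombesin receptor subtype-3 (Homo sapiens), read by luminescence and calcium flux, with a stated time of 10 min; a lower number here means that less compound is needed, a higher number that more compound is needed for the effect. Compound 1 `CCC(C)(C)Cc1c[nH]c(CCc2ccc(-c3cccnc3)cc2)n1` gives 131 nM. Compound 2 `CCC(C)(C)Cc1c[nH]c(CCc2ccc(-n3ccnn3)cc2)n1` gives 641 nM, and compound 3 `CCC(C)(C)Cc1c[nH]c(CCc2ccc(-c3cccnc3C(=O)O)cc2)n1` gives 1260 nM. Compound 3 carries the highest number of the three: the step of a 9.6-fold higher number from compound 1 to compound 3 (0.98 log units; beyond the scatter) is clearly beyond the scatter, whereas compound 2 sits closer, since a 2.0-fold higher number from compound 2 to compound 3 (0.29 log units; within the scatter) stays within the scatter of repeated measurements.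

Compound 4 `CCC(C)(C)Cc1c[nH]c(CCc2ccc(-n3cncn3)cc2)n1` takes compound 3 as its starting point and alters a single group: 1H-1,2,4-triazol-1-yl in place of 2-carboxypyridin-3-yl on an aromatic carbon. Among the compounds with values here, two measured steps bear on this change. The step of a 4.9-fold higher number from compound 1 to compound 2 (0.69 log units; beyond the scatter) shows a 1H-1,2,3-triazol-1-yl group on the same aromatic carbon giving a modestly higher number than pyridin-3-yl. The step of a 2.0-fold higher number from compound 2 to compound 3 (0.29 log units; within the scatter) shows that 2-carboxypyridin-3-yl and 1H-1,2,3-triazol-1-yl give numbers that cannot be told apart. The 1H-1,2,4-triazol-1-yl of compound 4 is closely related to the 1H-1,2,3-triazol-1-yl of compound 2, so because compound 2 gives 641 nM, compound 4 is expected to land near that figure, a step of a 2.1-fold lower number from compound 3 to compound 4 (0.32 log units; beyond the scatter) that may well stay within the scatter. The estimate for compound 4 is 600 nM, with a range from 250 nM to 1500 nM.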

Compound 4, half-maximal effective concentration: 570 nM
Compound 4: the middle estimate sits 1.1-fold (0.02 log units) above what was measured, within the range that was stated.
By their numbers in this assay, from the lowest: compound 1; then compounds 4, 2 and 3 (each within the scatter of the next, the first and the last beyond it).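

In this assay the two triazoles, 1H-1,2,4-triazol-1-yl and 1H-1,2,3-triazol-1-yl, cannot be told apart on this aromatic carbon (a 1.1-fold lower number from compound 2 to compound 4 (0.05 log units; within the scatter)), so the arrangement of the three ring nitrogens makes no readable difference here. The second triazole also confirms the gap to the six-membered ring of compound 1 (a 4.4-fold higher number from compound 1 to compound 4 (0.64 log units; beyond the scatter)), which now holds for both compound 2 and compound 4, while the exchange of 2-carboxypyridin-3-yl for this triazole (a 2.2-fold lower number from compound 3 to compound 4 (0.34 log units; beyond the scatter)) lies only just beyond the scatter, although compound 2 stays within the scatter of compound 3. No supporting data accompany these numbers to say what lies behind any of these differences.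

The compounds shown leave open whether the lower number of compound 1 belongs to the ring nitrogen of pyridin-3-yl or simply to a six-membered ring, which a plain phenyl group or a pyridin-4-yl group at the same place would help to separate. They also leave open whether the higher number of compound 3 is tied to the carboxylic acid itself, a question that a methyl ester or a primary amide on the same pyridine could address.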